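Series notes: antiproliferative screen at a single concentration

This account rests on a few compounds, and the source may have more. Where it says the series, first, only, none or still open, it means among the compounds named here.

Values in a functional assay on MDA-MB-231 cells (Homo sapiens) for antiproliferative activity, read by MTT assay, with a stated time of 72 h, tested at 10 uM; on this read-out lower numbers stand for less inhibition and higher numbers for more inhibition at the one concentration tested (going by the name of the read-out):
compound 1 `Fc1ccc(-c2nss/c2=N\c2ccccc2)cc1` gives 0%
compound 2 `c1ccc(/N=c2\ssnc2-c2cccs2)cc1` gives 0%

Compound 2 stands level with compound 1 at the digits shown; its nearest neighbour is compound 1, and the two agree within the scatter. Neither shows any inhibition in this assay at the one concentration tested. Among the compounds with values here, no step between measured compounds that differ in a single place is available, so nothing is known yet about how an exchange at this position moves the read-out.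

Compound 3 `CCOC(=O)c1nss/c1=N\c1ccccc1` is the next to be measured. It differs from compound 2 in one place: ethoxycarbonyl in place of thiophen-2-yl on an aromatic carbon. Both measured compounds give no inhibition in this assay, and nothing in these two values points to a shift beyond the scatter from this exchange. The step of a number 5 percentage points higher from compound 2 to compound 3 (within the scatter) is expected to stay within the scatter. For compound 3 the estimate in this assay is 5%, ranging from 0% to 20%.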

Compound 3, a percentage reported as inhibition, at one concentration (the size of the read-out at that concentration, not a potency): 0%
The estimate for compound 3 lay 5 percentage points above the measured number; low and high end bracket the measured number.
By their numbers in this assay, from the lowest: compounds 1, 2 and 3 (each within the scatter of the next).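

Ethoxycarbonyl in place of thiophen-2-yl on an aromatic carbon, next to the ring nitrogen, brings no change at the digits printed from compound 2 to compound 3 (within the scatter) in this assay. Within the data shown here, this is the first single-place step: a five-membered aromatic ring gives way to a group with no ring, and no inhibition appears on either side of the exchange. With no inhibition at either end, the step shows only that neither of these two groups brings inhibition at the one concentration tested, not how much this position can move the read-out. No measurement available here bears on this result.

Going by these compounds, whether an amine or a carboxylic acid on this aromatic carbon would bring any inhibition stays open. Also open, on these data alone, is whether any compound on the shared core gives inhibition in this assay.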